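The source may hold more compounds than are shown below. What is called first, only, known or untested is meant among the compounds shown, and "the series" means these compounds.

Compound 1 `CC1(C)Cc2c(ccc(C(=O)/C=C/c3ccc(Cl)cc3)c2OCc2ccccc2)O1`: in a functional assay on PC-3 cells (Homo sapiens) for antiproliferative activity, read by MTT assay, with a stated time of 48 h (on this read-out higher numbers stand for weaker inhibition and lower numbers for stronger inhibition), compound 1 reaches only the limit of > 100000 nM.
Compound 2 `CC1(C)Cc2c(ccc(C(=O)/C=C/c3ccc(F)cc3)c2OCc2ccccc2)O1`: in this assay compound 2 gives 44200 nM.

For the measured compounds named here, compound 2 therefore holds the only actual number in this assay, the other value being a limit. The change methoxy in place of fluoro on an aromatic carbon carries compound 2 to compound 3 `COc1ccc(/C=C/C(=O)c2ccc3c(c2OCc2ccccc2)CC(C)(C)O3)cc1`. Going by the values given here, the single measured step, an at least 2.2-fold lower number from compound 1 to compound 2 (0.35 log units; beyond the scatter), swaps one halogen for another and bears only loosely on a methoxy. Among the compounds with values here, no measured step tells how methoxy compares with fluoro, so a step of about a 1.1-fold lower number from compound 2 to compound 3 (0.04 log units; within the scatter) is expected, not beyond the scatter. Compound 3 is expected to give 40000 nM, within 15000 nM to 120000 nM.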

Compound 3, half-maximal inhibitory concentration: 48900 nM
Compound 3: the middle estimate sits 1.2-fold (0.09 log units) below what was measured, and the stated range covers the measured number.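

At this place on the aromatic ring, para to a large group, methoxy and fluoro are not told apart in this assay, with a 1.1-fold higher number from compound 2 to compound 3 (0.04 log units; within the scatter), even though two heavy atoms and a hydrogen-bond acceptor enter where one fluorine left. Methoxy, like fluoro, stands apart from chloro, with an at least 2.0-fold lower number from compound 1 to compound 3 (0.31 log units; beyond the scatter). That step is only a bound, as compound 1 gives a limit and not a number: the limit of > 100000 nM in this assay, at which 1 of the 3 values shown sits.

As far as these compounds go, what an amine or a carboxylic acid would do at this place remains open. So does how far chloro truly lies from methoxy and fluoro.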